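Removing a Methyl Group: From Compound 2 to Compound 3

This account rests on a few compounds, and the source may have more. Where it says the series, first, only, none or still open, it means among the compounds named here.

Of the compounds shown here, two have been measured. Compound 1 `CS(=O)(=O)c1ccc2sc(NC(=O)NC(=O)c3ccccc3Cl)nc2c1` and compound 2 `Cc1ccnn1-c1ccc(Cl)c(C(=O)NC(=O)Nc2nc3ccc(S(=O)(=O)C4CCN(C)CC4)cc3s2)c1` share a core that carries a urea linked to an acylated benzothiazole-type amine; the two differ in their side groups on both ends. In a physicochemical assay for lipophilicity (a lower number here means a more polar compound, a higher number a more lipophilic compound), compound 1 gives 2.8, and compound 2 gives 2.6. Compound 2 thus carries the lower of the two numbers, yet its distance from compound 1 falls within the scatter, so the two read as alike.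

Compound 3 `CN1CCC(S(=O)(=O)c2ccc3nc(NC(=O)NC(=O)c4cc(-n5cccn5)ccc4Cl)sc3c2)CC1` is a close relative of compound 2. The single difference between them is this: hydrogen in place of methyl on an aromatic carbon. For the measured compounds named here, no pair of measured compounds shows this change on its own, so no measured step can guide the size. The loss of one carbon without any change in donors, acceptors or charge is expected to leave the distribution coefficient nearly where it is, with a slight lowering at most, and the step from compound 2 to compound 3 is estimated at a number 0.20 log units lower from compound 2 to compound 3 (within the scatter). Compound 3 is therefore expected to give 2.4 in this assay, within a range from 2 to 2.8.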

Compound 3, distribution coefficient: 2.5
Estimate against measurement, compound 3: 0.10 log units below; the range from low to high includes it.
By their numbers in this assay, from the lowest: compounds 3, 2 and 1 (each within the scatter of the next).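

Replacing methyl with hydrogen on an aromatic carbon of the five-membered aromatic ring with 2 nitrogen, the change from 5-methyl-1H-pyrazol-1-yl to 1H-pyrazol-1-yl, gives a number 0.10 log units lower from compound 2 to compound 3 (within the scatter) in this assay. For the compounds shown here, this is the first step that can be read at a single place, since compound 1 and compound 2 differ at both ends and could not show what this methyl alone contributes to the reading. At this position, compound 2 and compound 3 therefore read as alike, and the methyl can give way to hydrogen without a step beyond the scatter, although nothing shown gives a measured account of why the reading behaves this way.

What the compounds shown leave open is whether this position stays as undemanding in this assay when it carries something other than methyl or hydrogen, such as a longer alkyl chain, an amine or a carboxylic acid. They also leave open whether the same exchange of methyl for hydrogen would read alike on another core or at another place on the molecule.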